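The source may hold more compounds than are shown below. What is called first, only, known or untested is meant among the compounds shown, and "the series" means these compounds.

Measured so far in an ADME assay on HEK-293T cells (Homo sapiens) for cytotoxicity, read by MTT assay, with a stated time of 24 h; a lower number here means that less compound is tolerated, a higher number that more compound is tolerated:

compound 1, `Cc1ccc(-c2nn(-c3ccccc3)cc2-c2nc3ccccc3n2C(=O)c2ccccc2C)cc1`: 176000 nM
compound 2, `Cc1ccccc1C(=O)n1c(-c2cn(-c3ccccc3)nc2-c2ccc(F)cc2)nc2ccccc21`: 189000 nM
compound 3, `Cc1ccccc1C(=O)n1c(-c2cn(-c3ccccc3)nc2-c2ccc(C(F)(F)F)cc2)nc2ccccc21`: 179000 nM

Compound 1 stands at the low end of these three numbers, but the gaps to the other two are small: a 1.1-fold higher number from compound 1 to compound 2 (0.03 log units; within the scatter) and a 1.0-fold higher number from compound 1 to compound 3 (0.01 log units; within the scatter), and between the other two a 1.1-fold lower number from compound 2 to compound 3 (0.02 log units; within the scatter). All three compounds share the same core and differ only in the group on an aromatic carbon of the outer ring, and none of those changes moved this assay beyond its scatter.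

Compound 4, `Cc1ccc(C(=O)n2c(-c3cn(-c4ccccc4)nc3-c3ccc(C)cc3)nc3ccccc32)cc1`, has not yet been measured in this assay. It is built from the same atoms as compound 1, joined differently: 4-methylphenyl in place of 2-methylphenyl on a carbonyl carbon. Within the data shown here, this change sits at the carbonyl attached to the core, a place none of the measured steps touches, so there is no direct precedent among the three. What the measured steps do show is that every substitution tried so far left this assay flat, and nothing in the data points to a larger effect here. For compound 4 the expected step is therefore no change at the digits printed from compound 1 to compound 4 (within the scatter), meaning no change beyond the scatter. The estimate for compound 4 is 176000 nM, with a range from 100000 nM to 310000 nM.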

Compound 4, half-maximal cytotoxic concentration: 176000 nM
Compound 4: middle estimate and measured number agree at the digits printed; measured number inside the range.
By their numbers in this assay, from the lowest: compounds 1, 4, 3 and 2 (each within the scatter of the next).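

Putting 4-methylphenyl in place of 2-methylphenyl on a carbonyl carbon gives no change at the digits printed from compound 1 to compound 4 (within the scatter) in this assay. Among these compounds, the earlier compounds differed only at an aromatic carbon of the outer ring, so this is the first reading at the carbonyl end of the molecule, and it shows that rearranging the same atoms at this place, with the methyl group shifted around the ring, leaves the number within the scatter as well. No measurement at hand bears on why the two compounds read alike.

From the compounds shown here alone, both groups seen on this carbonyl carbon are methylphenyl rings, so one pair says little about the position as a whole, and it remains open whether a quite different group there, such as a pyridine ring, a simple amine or a longer alkyl chain, would also read alike. The outer ring is equally open, since the three groups shown there are methyl, fluoro and trifluoromethyl, and a carboxylic acid or an amine in their place might or might not stay within the scatter.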